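Moving the dimethylamino group around a methylphenyl ether

A few compounds are considered here, and "the series" means these few. Any claim that something is new, unique, unknown or untested is made for them only; others in the source may bear on it.

Three compounds with a shared core carry an amidine-bearing phenyl ether and differ at the second ether. Compound 1 `Cc1c(F)c(Oc2cccc(C(=N)N)c2)nc(Oc2cccc([N+](=O)[O-])c2)c1F` carries a 3-nitrophenyl on that oxygen; in an assay on isolated protein for inhibition of serine protease 1 (Bos taurus) (a higher number here means a weaker inhibitor, a lower number a stronger inhibitor), compound 1 gives only a limit, > 5000 nM. Compound 2 `Cc1c(F)c(Oc2cccc(CCC(=O)N(C)C)c2)nc(Oc2cccc(C(=N)N)c2)c1F` gives 4900 nM in this assay, and compound 3 `Cc1c(Oc2nc(Oc3cccc(C(=N)N)c3)c(F)c(C)c2F)cccc1N(C)C` gives 5000 nM. On the numbers shown, compound 3 stands highest of the two, with compound 2 nearest, and the two lie within the scatter of each other.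

Compound 4 `Cc1ccc(N(C)C)cc1Oc1nc(Oc2cccc(C(=N)N)c2)c(F)c(C)c1F` differs from compound 3 only in the placement of the dimethylamino group: 5-(dimethylamino)-2-methylphenyl in place of 3-(dimethylamino)-2-methylphenyl on an oxygen on an aromatic ring. Going by the values given here, no measured step changes the position of a substituent on this ether; the step of an at least 1.0-fold lower number from compound 1 to compound 2 (0.00 log units; that floor lies within the scatter) concerns a different part of the molecule, and the step of a number no higher from compound 1 to compound 3 (the limit leaves the size open) starts from the limit (the limit of > 5000 nM in this assay, at which 1 of the 3 values shown sits), so its size is not readable. Neither therefore points in any direction for this change. The expectation for compound 4 in this assay is a step of no change at the digits printed from compound 3 to compound 4 (within the scatter), nothing beyond the scatter. Compound 4 is expected to give about 5000 nM, within the range 1500 nM to 15000 nM.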

Compound 4, inhibition constant: > 5000 nM
Compound 4: no number, only a limit; the forecaster's own chance of this, stated with the estimate: 40%; the middle value sits exactly at the limit.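

In this assay compound 4 gives only a limit, > 5000 nM, so moving the dimethylamino group yields no number to set beside compound 3. The change from 3-(dimethylamino)-2-methylphenyl to 5-(dimethylamino)-2-methylphenyl on this oxygen gives a number no lower from compound 3 to compound 4 (the limit leaves the size open), which fixes a direction and nothing more, and the step joining compound 1 to compound 4 has a limit at both ends and cannot be read. This position change adds a second compound to those that reach the limit of the assay: the limit of > 5000 nM in this assay, at which 2 of the 4 values shown sit.

From the compounds shown here alone, how far compound 4 lies from compound 3 stays open, and so does whether the placement of the dimethylamino group matters at all in this assay. Also open, going by these compounds, is what a primary amine or a carboxylic acid would give in place of the dimethylamino group on this methylphenyl ether.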